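The compounds below may be only part of what the source reports. "The series", "measured", "known", "first", "only" and "open" are said of these compounds alone.

Measured so far in a functional assay on CHO-K1 cells for agonist activity at Glucose-dependent insulinotropic receptor (Mus musculus), read by HTRF and cAMP accumulation, with a stated time of 30 min; on this read-out higher numbers stand for larger maximal responses and lower numbers for smaller maximal responses:

compound 1, `CCc1cnc(N2CCC(CCCNc3ccc4c(c3)C(=O)CC4)CC2)nc1`: 110%
compound 2, `CC(C)(C)OC(=O)N1CCC(CCCNc2ccc3c(c2)OCC3=O)CC1`: 108%
compound 3, `CC(C)(C)OC(=O)N1CCC(CCCNc2ccc3c(c2)C(=O)CC3)CC1`: 110%

All three compounds reach a maximal response close to the reference. Compound 1 is obtained from compound 3 by 5-ethylpyrimidin-2-yl in place of tert-butoxycarbonyl on an amine nitrogen in a ring, and in this assay this gives no change at the digits printed from compound 3 to compound 1 (within the scatter). Compound 2 and compound 3 carry different cores; how the two cores differ is not broken down here. Their values in this assay lie within the usual scatter of each other.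

Compound 4, `CCc1cnc(N2CCC(CCCNc3ccc4c(c3)OCC4=O)CC2)nc1`, is not yet measured. It arises from compound 2 by 5-ethylpyrimidin-2-yl in place of tert-butoxycarbonyl on an amine nitrogen in a ring, which is the same change as that from compound 3 to compound 1, made at the same place on the ring nitrogen. Going by the values given here, on the core of compound 3 that change left the maximal response unchanged within the scatter, as no change at the digits printed from compound 3 to compound 1 (within the scatter) shows; nothing among the measured compounds points to a different outcome on the core of compound 2. The step expected in this assay is therefore no change at the digits printed from compound 2 to compound 4 (within the scatter). On that basis compound 4 is estimated to give 108%, most likely between 98% and 118%.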

Compound 4, largest response reached (Emax), in percent of the reference or control that the assay uses: 98%
The estimate for compound 4 lay 10 percentage points above the measured number; the range from low to high includes it.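

In this assay, 5-ethylpyrimidin-2-yl in place of tert-butoxycarbonyl on the ring nitrogen gives a number 10 percentage points lower from compound 2 to compound 4 (within the scatter). Set beside the same change on the core of compound 3, the two outcomes do not separate: the same change on two cores in this assay, no change at the digits printed (within the scatter) from compound 3 to compound 1 and a number 10 percentage points lower (within the scatter) from compound 2 to compound 4, 10 percentage points apart, within the scatter of two such steps. This shows that, on these two cores, the change leaves the maximal response within the scatter, but it does not establish that the two cores respond identically, that the same would hold on any further core, or anything about the concentration needed to reach that response.

Going by these compounds alone, open is how far the ring nitrogen tolerates other groups, for example a 5-chloropyrimidin-2-yl or a benzyl group in place of the 5-ethylpyrimidin-2-yl, since only two groups on that nitrogen appear here. Also open is whether the maximal response holds with a longer chain or with an amide in place of the secondary amine, as every compound shown keeps the same chain and amine.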